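Three chloroacetamide-derived analogues and a piperazine successor

This account rests on a few compounds, and the source may have more. Where it says the series, first, only, none or still open, it means among the compounds named here.

Compound 1 `Cn1c(-c2ccc(NC(=O)CCl)cc2)nc(-c2ccccc2)c1-c1ccccc1` gives 7.2% in a functional assay on HT-29 cells (Homo sapiens) for cytotoxicity, read by MTT assay, with a stated time of 24 h, tested at 0.64 ug/mL; on this read-out lower numbers stand for a weaker effect and higher numbers for a stronger effect at the one concentration tested.
Compound 2 `Cn1c(-c2ccc(NC(=O)CSc3nc4cc(Cl)ccc4o3)cc2)nc(-c2ccccc2)c1-c1ccccc1` gives 11.9% in this assay.
Compound 3 `Cn1c(-c2ccc(NC(=O)CSC3=NCCS3)cc2)nc(-c2ccccc2)c1-c1ccccc1` gives 16.8% in this assay.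

All three compounds share the same core and differ only in the group on a saturated chain carbon bound to a carbonyl carbon. Compound 3 carries the highest of the three numbers, yet its separation from compound 2 a number 4.9 percentage points higher from compound 2 to compound 3 (within the scatter) and from compound 1 a number 9.6 percentage points higher from compound 1 to compound 3 (within the scatter) each stays within the scatter, so no ordering among them can be read from these figures. The change from compound 1 to compound 2 a number 4.7 percentage points higher from compound 1 to compound 2 (within the scatter) is likewise within the scatter.

Compound 4 `CN(C)/C=C/N1CCN(CC(=O)Nc2ccc(-c3nc(-c4ccccc4)c(-c4ccccc4)n3C)cc2)CC1` is not yet measured. It differs from compound 3 by a group of 11 heavy atoms (8 carbon, 3 nitrogen; one six-membered non-aromatic ring with 2 hetero atoms) in place of a group of 6 heavy atoms (3 carbon, 1 nitrogen, 2 sulfur; one five-membered non-aromatic ring with 2 hetero atoms), on a saturated chain carbon bound to a carbonyl carbon. Every measured step at this same place has been within the scatter, so there is no reason from these compounds to expect a step beyond it here. The step from compound 3 to compound 4 in this assay is therefore estimated as a number 2.8 percentage points lower from compound 3 to compound 4 (within the scatter). Compound 4 is expected to give about 14%, with a range from 3% to 27%.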

Compound 4, a percentage reported as activity, at one concentration (the size of the read-out at that concentration, not a potency): 3.1%
For compound 4 the middle estimate is 10.9 percentage points above the measured one; the range from low to high includes it.
By their numbers in this assay, from the lowest: compounds 4, 1, 2 and 3 (each within the scatter of the next, the first and the last beyond it).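

In this assay the group on a saturated chain carbon bound to a carbonyl carbon now gives its first step beyond the scatter, with 4-(2-(dimethylamino)ethenyl)piperazin-1-yl entering for the five-membered non-aromatic ring group as a number 13.7 percentage points lower from compound 3 to compound 4 (beyond the scatter), so a change at this place can separate two compounds on this read-out. The separation is confined to that one pair, since the same entering group gives a number 8.8 percentage points lower from compound 2 to compound 4 (within the scatter) against (5-chloro-1,3-benzoxazol-2-yl)sulfanyl and a number 4.1 percentage points lower from compound 1 to compound 4 (within the scatter) against chloro, and both of these steps lie within the scatter. The counts of hydrogen-bond donors and acceptors are the same in the leaving and entering groups, and nothing available bears on why this step arises.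

The compounds shown leave open whether the step belongs to the six-membered ring or to the 2-(dimethylamino)ethenyl chain on it, which a plain piperazin-1-yl or a 4-methylpiperazin-1-yl at the same place would help to separate. They also leave open how these compounds compare in potency, as every number comes from a single concentration.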